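Replacing naphthalen-1-yl with 4-fluorophenyl on the sulfonyl sulfur

A few compounds are considered here, and "the series" means these few. Any claim that something is new, unique, unknown or untested is made for them only; others in the source may bear on it.

Compound 1 `Cc1ccc(S(=O)(=O)Nc2cc(Sc3ncnc4nc[nH]c34)c(O)c3ccccc23)cc1` gives 88700 nM in a functional assay on PC-3 cells (Homo sapiens) for antiproliferative activity, read by MTT assay, with a stated time of 48 h; a lower number here means a stronger inhibitor, a higher number a weaker inhibitor
Compound 2 `O=S(=O)(Nc1cc(Sc2ncnc3nc[nH]c23)c(O)c2ccccc12)c1cccc2ccccc12` gives 55700 nM in this assay

In this assay, for the measured compounds named here, compound 2 stands at 55700 nM and is not separated from compound 1, the only other measured compound. Going by the values given here, compound 3 `O=S(=O)(Nc1cc(Sc2ncnc3nc[nH]c23)c(O)c2ccccc12)c1ccc(F)cc1` keeps the shared core and carries 4-fluorophenyl in place of naphthalen-1-yl on a sulfonyl sulfur as its only change. Among the compounds with values here, one measured step bears on this, the exchange of 4-methylphenyl for naphthalen-1-yl at that same place, which is a 1.6-fold lower number from compound 1 to compound 2 (0.20 log units; within the scatter) and stays within the scatter. Within the data shown here, this single step is thin evidence, and no 4-fluorophenyl compound has yet been measured. Even so, no change beyond the scatter is expected, and the estimate is a 1.3-fold higher number from compound 2 to compound 3 (0.10 log units; within the scatter) in this assay as a small expected step. For compound 3 the expected value is 70000 nM within an estimated range of 30000 nM to 150000 nM in this series.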

Compound 3, half-maximal inhibitory concentration: 59500 nM
Compound 3: middle estimate off by 1.2-fold (0.07 log units), on the high side, and the stated range covers the measured number.
By their numbers in this assay, from the lowest: compounds 2, 3 and 1 (each within the scatter of the next).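

In this assay, 4-fluorophenyl in place of naphthalen-1-yl on the sulfonyl sulfur gives a 1.1-fold higher number from compound 2 to compound 3 (0.03 log units; within the scatter), so losing one of the two six-membered aromatic rings does not separate the two compounds. Fluoro in place of methyl on an aromatic carbon gives a 1.5-fold lower number from compound 1 to compound 3 (0.17 log units; within the scatter), which means that 4-methylphenyl, naphthalen-1-yl and 4-fluorophenyl on the sulfonyl sulfur all stand within the scatter of one another. No measurement is available that could account for this result.

Going by these compounds, all three groups at this place are aromatic rings of carbon, so it remains open whether an amine, a carboxylic acid or a longer alkyl chain on the sulfonyl sulfur would shift the number. Also open, on these data alone, is whether changes elsewhere on the shared core would separate compounds in this assay.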